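This account rests on a few compounds, and the source may have more. Where it says the series, first, only, none or still open, it means among the compounds named here.

Measured compounds:
compound 1 `CC1=CC[C@H](C(C)(C)NC(=S)N/N=C/c2ccccc2Cl)CC1` with 81000 nM
compound 2 `CC1=CC[C@H](C(C)(C)NC(=S)N/N=C/c2cccc(Cl)c2)CC1` with 21400 nM
compound 3 `CC1=CC[C@H](C(C)(C)NC(=S)N/N=C/c2ccccc2[N+](=O)[O-])CC1` with 32700 nM

These three share a core and differ only in the aromatic ring attached to it. All were tested in a functional assay on NCI-H460 cells (Homo sapiens) for inhibition, read by sulforhodamine B assay, with a stated time of 48 h; on this read-out lower numbers stand for stronger inhibition of growth and higher numbers for weaker inhibition of growth. Compound 2 differs from compound 1 in that the two have the same atoms, joined differently: 3-chlorophenyl in place of 2-chlorophenyl on a carbon with a double bond to nitrogen. This gave a 3.8-fold lower number from compound 1 to compound 2 (0.58 log units; beyond the scatter). Compound 3 differs from compound 1 by nitro in place of chloro on an aromatic carbon, which gave a 2.5-fold lower number from compound 1 to compound 3 (0.39 log units; beyond the scatter). Compound 2 and compound 3 are within the scatter of each other.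

Compound 4 `CC1=CC[C@H](C(C)(C)NC(=S)N/N=C/c2cccc([N+](=O)[O-])c2)CC1` has not been measured. It differs from compound 2 by nitro in place of chloro on an aromatic carbon. Within the data shown here, this is the same kind of change as the one from compound 1 to compound 3, but the place differs: there the nitro sits ortho to a large group, here meta to a large group. If the change behaves as it did between compound 1 and compound 3, a step of similar size would follow. Because a 2.5-fold lower number from compound 1 to compound 3 (0.39 log units; beyond the scatter) was modest, the expected step for compound 4 is a 1.8-fold lower number from compound 2 to compound 4 (0.25 log units; within the scatter). Compound 4 is estimated at 12000 nM. The lower end of that expectation for compound 4 is 5000 nM. The upper end expected for compound 4 is estimated at 35000 nM.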

Compound 4, concentration for total growth inhibition: > 100000 nM
Compound 4 was reported as a limit (the forecaster's own chance of this, stated with the estimate: 5%); middle value at least 8.3-fold (0.92 log units) away from the limit.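

In this assay compound 4 gives > 100000 nM, which is a limit of the assay and not a number. Nitro in place of chloro does not carry over from one core to the other in this series, as an at least 4.6-fold higher number from compound 2 to compound 4 (0.66 log units; beyond the scatter) runs in the opposite direction to a 2.5-fold lower number from compound 1 to compound 3 (0.39 log units; beyond the scatter): the same change on two cores in this assay, a 2.5-fold lower number (0.39 log units; beyond the scatter) from compound 1 to compound 3 and an at least 4.6-fold higher number (0.66 log units; beyond the scatter) from compound 2 to compound 4, at least 11-fold (1.06 log units) apart, beyond the scatter of two such steps Two pairs cannot give a general rule or show why the direction reverses, and the full size of the new step stays unknown because the reading for compound 4 is a limit: the limit of > 100000 nM in this assay, at which 1 of the 4 values shown sits.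

The compounds shown leave open whether other groups placed meta to a large group, such as an amine or a carboxylic acid, would follow compound 2 or compound 4. They also leave open whether a methoxy or fluoro group in place of chloro would show a similar reversal between the two cores.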